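The source may hold more compounds than are shown below. What is called first, only, known or untested is meant among the compounds shown, and "the series" means these compounds.

Compound 1, `COc1cc(/C=C/C(=O)O)ccc1OC(C)=O`, sits at the edge of what the measurement can report. In a functional assay, read by spectrophotometry, with a stated time of 30 min (on this read-out lower numbers stand for stronger inhibition and higher numbers for weaker inhibition), compound 1 gives only a limit, > 500000 nM, not a number. Going by the values given here, compound 2, `CCOC(=O)[C@@H](NC(=O)/C=C/c1ccc(O)c(O)c1)[C@@H](C)CC`, is the only compound with an actual number: in this assay compound 2 gives 43500 nM. Compound 3, `CCOC(=O)[C@H](CC(C)C)NC(=O)/C=C/c1ccc(O)c(O)c1`, has not yet been measured. Compound 3 differs from compound 2 in one place: isobutyl in place of sec-butyl on a saturated chain carbon bound to an amide-type nitrogen and a carbonyl carbon. The two side groups are the same atoms joined differently, and the amide and the ester stay untouched. Among the compounds with values here, no measured pair here differs in one place, so there is no measured step to lean on. The change from compound 2 to compound 3 is expected to stay within the scatter of repeated measurements in this assay, in no particular direction. Compound 3 is therefore expected to give about 45000 nM, with a likely range from 15000 nM to 135000 nM. This estimate amounts to an expected step of a 1.0-fold higher number from compound 2 to compound 3 (0.01 log units; within the scatter).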

Compound 3, half-maximal inhibitory concentration: 28600 nM
Compound 3: middle estimate off by 1.6-fold (0.20 log units), on the high side; the range from low to high includes it.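

Going by these compounds alone, the swap of sec-butyl for isobutyl on this saturated chain carbon gives a 1.5-fold lower number from compound 2 to compound 3 (0.18 log units; within the scatter), and this is the first measured step in the set that changes one place only. Although the atoms are joined differently and the defined stereocentre of the sec-butyl group is gone, compound 2 and compound 3 cannot be told apart in this assay. Compound 1 remains a limit and not a number, so it adds no step to this comparison: the limit of > 500000 nM in this assay, at which 1 of the 3 values shown sits.

Within the data shown here, what a longer chain, a benzyl group or a carboxylic acid on this same carbon would give remains open, since sec-butyl and isobutyl are the only groups seen there. One pair also cannot tell whether this swap would read the same way on a different core.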